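The source may report more compounds than this note shows. Statements on the series, on what has been measured and on what is new or still open speak of the compounds shown alone.

Going by the values given here, compound 1 `COc1ccc(-c2cc3nccc(-c4cc(OC)c(OC)c(OC)c4)n3n2)cc1N` gives 138 nM in a functional assay on A549 cells (Homo sapiens) for inhibition, read by CCK-8 assay, with a stated time of 48 h (on this read-out lower numbers stand for stronger inhibition and higher numbers for weaker inhibition), the second highest of the three numbers measured so far. Compound 2 `COc1cc(-c2ccnc3cc(-c4c[nH]c5ccccc45)nn23)cc(OC)c1OC` gives 29 nM in this assay, and compound 3 `COc1cc(-c2ccnc3cc(-c4ccc5cnn(C)c5c4)nn23)cc(OC)c1OC` gives 233 nM. Both differ from compound 1 at the same aromatic carbon: a 4.8-fold lower number from compound 1 to compound 2 (0.68 log units; beyond the scatter), whereas a 1.7-fold higher number from compound 1 to compound 3 (0.23 log units; within the scatter); between those two, an 8.0-fold higher number from compound 2 to compound 3 (0.90 log units; beyond the scatter). Compound 4 `COc1cc(-c2ccnc3cc(-c4ccc5c(ccn5C)c4)nn23)cc(OC)c1OC` changes compound 1 at that carbon as well: 1-methyl-1H-indol-5-yl in place of 3-amino-4-methoxyphenyl on an aromatic carbon. The two steps from compound 1 bear on it, one a modest gain, one within the scatter. The 1-methyl-1H-indol-5-yl group carries the same methyl as the 1-methyl-1H-indazol-6-yl of compound 3 and otherwise resembles the 1H-indol-3-yl of compound 2, so a step within the scatter or a small lowering is expected, a 1.3-fold lower number from compound 1 to compound 4 (0.10 log units; within the scatter). Compound 4 is estimated at 110 nM, with a range of 35 nM to 350 nM.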

Compound 4, half-maximal inhibitory concentration: 15 nM
For compound 4 the middle estimate is 7.3-fold (0.87 log units) above the measured one; measured number outside the range, below it.
By their numbers in this assay, from the lowest: compounds 4 and 2 (each within the scatter of the next); then compounds 1 and 3 (each within the scatter of the next).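

With 1-methyl-1H-indol-5-yl at this carbon, a 9.2-fold lower number from compound 1 to compound 4 (0.96 log units; beyond the scatter), so a group with 0 hydrogen-bond donors can replace 3-amino-4-methoxyphenyl with a gain. The step from the 1H-indol-3-yl group stays small, a 1.9-fold lower number from compound 2 to compound 4 (0.29 log units; within the scatter), while the step from the closely similar 1-methyl-1H-indazol-6-yl group is large, a 16-fold lower number from compound 3 to compound 4 (1.19 log units; beyond the scatter), so having two fused aromatic rings does not by itself set the number, and compound 3 goes against any such reading.

Nothing available explains these gaps. Still open, from the compounds shown here alone, are the separate parts played by the indole's attachment point and its methyl, and how an indole bearing a carboxylic acid or a longer amine chain would read.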